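The source may report more compounds than this note shows. Statements on the series, on what has been measured and on what is new or still open speak of the compounds shown alone.

Compound 1, `Cc1c(C(=O)Nc2ccc(Oc3ccnc4[nH]ccc34)cc2)nnn1-c1ccccc1`, is the starting point. In a functional assay on A549 cells (Homo sapiens) for cytotoxicity, read by MTT assay, with a stated time of 72 h (a higher number here means a weaker inhibitor, a lower number a stronger inhibitor), compound 1 gives 420 nM. Compound 2, `Cc1c(C(=O)Nc2ccc(Oc3ccnc4[nH]ccc34)cc2)nnn1-c1ccc(F)c(F)c1`, differs from it in one place: 3,4-difluorophenyl in place of phenyl on an aromatic nitrogen. That change produced a 5.4-fold higher number from compound 1 to compound 2 (0.73 log units; beyond the scatter), and compound 2 gives 2260 nM in this assay. Compound 3, `O=C(Nc1ccc(Oc2ccnc3[nH]ccc23)c(F)c1)c1nnn(-c2ccccc2)c1C(F)(F)F`, has a different core, and the difference between the two cores is not broken down here. In this assay compound 3 gives 220 nM, a number that lies within the scatter of compound 1. Compound 4, `O=C(Nc1ccc(Oc2ccnc3[nH]ccc23)c(F)c1)c1nnn(-c2ccc(F)c(F)c2)c1C(F)(F)F`, has not yet been measured. It is made from compound 3 by the same kind of change that led from compound 1 to compound 2: 3,4-difluorophenyl in place of phenyl on an aromatic nitrogen. The surroundings are not identical, since in compound 1 the aromatic nitrogen sits next to the ring atom that bears a methyl group, while in compound 3 that ring atom bears a trifluoromethyl group. Among the measured compounds shown here, the step is expected to be a 4.5-fold higher number from compound 3 to compound 4 (0.66 log units; beyond the scatter), an expectation resting on the single earlier example a 5.4-fold higher number from compound 1 to compound 2 (0.73 log units; beyond the scatter). Compound 4 is therefore estimated at 1000 nM, between 400 nM and 2500 nM.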

Compound 4, half-maximal inhibitory concentration: 350 nM
Compound 4: the middle estimate sits 2.9-fold (0.46 log units) above what was measured; the whole stated range lies above it.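

On the core of compound 3, putting 3,4-difluorophenyl in place of phenyl on the aromatic nitrogen gives a 1.6-fold higher number from compound 3 to compound 4 (0.20 log units; within the scatter) in this assay, so this step cannot be told apart from repeat-measurement noise. The size of the earlier step therefore did not carry over unchanged, and the two cores respond differently to the same change: the same change on two cores in this assay, a 5.4-fold higher number (0.73 log units; beyond the scatter) from compound 1 to compound 2 and a 1.6-fold higher number (0.20 log units; within the scatter) from compound 3 to compound 4, 3.4-fold (0.53 log units) apart, beyond the scatter of two such steps

This rests on a single pair of compounds per core, so it shows neither a general rule for the series nor why the two steps differ, and nothing here separates the trifluoromethyl group from any other difference between the cores.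

The compounds shown leave open how a phenyl ring carrying a single chlorine, a methoxy group or an amine would behave on the aromatic nitrogen of either core. As far as these compounds go, it also remains open whether swapping methyl for trifluoromethyl alone, with the rest of the core kept the same, would be enough to alter the step.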